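Isopropyl for Methyl in a Series That Stays at the Limit

The source may report more compounds than this note shows. Statements on the series, on what has been measured and on what is new or still open speak of the compounds shown alone.

Compound 1, `CC(C)[C@H](NC(=O)c1ccc(Cl)cc1O)C(=O)Nc1ccc(Cl)c(Cl)c1`: > 10000 nM
Compound 2, `C[C@H](NC(=O)c1ccc(Cl)cc1O)C(=O)Nc1ccc(Cl)c(Cl)c1`: > 12500 nM
Compound 3, `C[C@H](NC(=O)c1cc(Cl)ccc1O)C(=O)Nc1cccc(Cl)c1`: > 10000 nM

All three measured compounds were tested in a functional assay on K562 cells (Homo sapiens) for cytotoxicity, with a stated time of 72 h; on this read-out higher numbers stand for weaker inhibition and lower numbers for stronger inhibition. For compound 1 the value > 10000 nM is a limit of the assay, not a number. For compound 2 the value > 12500 nM is likewise a limit. For compound 3 the value > 10000 nM is also only a limit.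

Compound 2 and compound 1 share a core and differ in one place: isopropyl in place of methyl on a saturated chain carbon bound to an amide-type nitrogen and a carbonyl carbon. The step that the two limits leave unreadable from compound 2 to compound 1 cannot be read because the limit of > 10000 nM in this assay, at which 2 of the 3 values shown sit, and the limit of > 12500 nM in this assay, at which 1 of the 3 values shown sits, cap both values, so nothing can be said about its size or direction.

Compound 3 carries a different core; how it differs from the core of compound 2 is not broken down here. Compound 4, `CC(C)[C@H](NC(=O)c1cc(Cl)ccc1O)C(=O)Nc1cccc(Cl)c1`, has not yet been measured in this assay. It stands to compound 3 as compound 1 stands to compound 2: isopropyl in place of methyl on a saturated chain carbon bound to an amide-type nitrogen and a carbonyl carbon. The place of the change is the same in both pairs, so this is the same change.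

Compound 3 sits only at a limit, > 10000 nM. The earlier instance of the change gave no readable size, a step that the two limits leave unreadable from compound 2 to compound 1. On these grounds the expected step is a step that the limit leaves unreadable from compound 3 to compound 4, and compound 4 is expected to return only a limit as well. The estimate for compound 4 is 20000 nM, with a range from 8000 nM to 60000 nM.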

Compound 4, half-maximal inhibitory concentration: > 10000 nM
Compound 4 gave a limit, no number; the forecaster's own chance of this, stated with the estimate: 80%; the middle value is on the limit's open side.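

No new step can be read between compound 3 and compound 4, because both results are only limits, not numbers: the limit of > 10000 nM in this assay, at which 3 of the 4 values shown sit.

With every value shown being a limit, the compounds leave open how strongly any of them acts in this assay, and whether isopropyl in place of methyl changes that strength at all.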